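Exchanging a dimethylphenyl for naphthalen-1-yl: expected cytotoxicity

This account rests on a few compounds, and the source may have more. Where it says the series, first, only, none or still open, it means among the compounds named here.

Compound 1 `Cc1ccc(C)c(C(=O)Nc2cc(Cl)ccc2OCC(=O)Nc2ccc(S(N)(=O)=O)cc2C)c1` gives 79700 nM in a functional assay on C8166 cells (Homo sapiens) for cytotoxicity, read by MTT assay; on this read-out higher numbers stand for lower toxicity in this test and lower numbers for higher toxicity in this test. Compound 2 `Cc1cc(C)cc(C(=O)Nc2cc(Cl)ccc2OCC(=O)Nc2ccc(S(N)(=O)=O)cc2C)c1` gives 36500 nM in this assay, the lower of the two numbers, after a 2.2-fold lower number from compound 1 to compound 2 (0.34 log units; beyond the scatter). Compound 3 `Cc1cc(S(N)(=O)=O)ccc1NC(=O)COc1ccc(Cl)cc1NC(=O)c1cccc2ccccc12` differs from compound 2 by naphthalen-1-yl in place of 3,5-dimethylphenyl on a carbonyl carbon. For the measured compounds named here, the only measured step, which swaps one dimethylphenyl for another, bears on this change only loosely, and no step that brings in a naphthalen-1-yl has been measured, so a step of only modest size, in either direction, is expected. Compound 3 is estimated at 30000 nM, between 10000 nM and 90000 nM, which means an expected step of a 1.2-fold lower number from compound 2 to compound 3 (0.09 log units; within the scatter).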

Compound 3, half-maximal cytotoxic concentration: > 381000 nM
Compound 3: no number, only a limit (the forecaster's own chance of this, stated with the estimate: 10%); middle value at least 12-fold (1.10 log units) from the limit.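

In this assay, the entry for compound 3 is a limit of the assay and not a number: the limit of > 381000 nM in this assay, at which 1 of the 3 values shown sits. Naphthalen-1-yl on this carbonyl carbon gives an at least 10-fold higher number from compound 2 to compound 3 (1.01 log units; beyond the scatter) and an at least 4.7-fold higher number from compound 1 to compound 3 (0.67 log units; beyond the scatter), both towards lower toxicity in this test. So this position can shift the read-out much further than the swap between dimethylphenyl groups showed.

From the compounds shown here alone, whether this shift needs the second aromatic ring or only the absence of the methyl groups stays open. An unsubstituted phenyl or a naphthalen-2-yl at this position could help separate the two.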